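Piperidine in Place of Trifluoromethylsulfinyl: Cytotoxicity Expected

A few compounds are considered here, and "the series" means these few. Any claim that something is new, unique, unknown or untested is made for them only; others in the source may bear on it.

Compound 2 `Cc1c(-c2ccc(Cc3ccc([S+]([O-])C(F)(F)F)cc3)cc2)[nH]c2cccc(F)c2c1=O` was tested in an ADME assay on Huh7.5.1 cells (Homo sapiens) for cytotoxicity, read by WST assay, with a stated time of 48 h; on this read-out higher numbers stand for lower toxicity in this test and lower numbers for higher toxicity in this test. There compound 2 gives > 5000 nM, which is a limit of the assay and not a number, so compound 2 sits at the limit of > 5000 nM in this assay, at which 1 of the 3 values shown sits. Compound 1 `Cc1c(-c2ccc(Cc3ccc(C(C)(O)C(F)(F)F)cc3)cc2)[nH]c2cccc(F)c2c1=O` likewise gives only a limit, > 2500 nM. Compound 3 `Cc1c(-c2ccc(Cc3ccc(S(=N)(=O)C(F)(F)F)cc3)cc2)[nH]c2cccc(F)c2c1=O` also gives only a limit, > 10000 nM. The steps that touch compound 2 are a step that the two limits leave unreadable from compound 1 to compound 2 and a step that the two limits leave unreadable from compound 2 to compound 3; neither has a readable size. Compound 4 `Cc1c(-c2ccc(Cc3ccc(N4CCCCC4)cc3)cc2)[nH]c2cccc(F)c2c1=O` differs from compound 2 by a group of 6 heavy atoms (5 carbon, 1 nitrogen; one six-membered non-aromatic ring with 1 hetero atom) in place of a group of 6 heavy atoms (1 carbon, 1 oxygen, 3 fluorine, 1 sulfur; no ring), on an aromatic carbon. Among the compounds with values here, no measured step therefore tells how large a change to expect in this assay, in which direction, or whether any lies beyond the scatter. Compound 4 is expected to give about 10000 nM, estimated between 3000 nM and 30000 nM. The expected step is a step that the limit leaves unreadable from compound 2 to compound 4, most likely again reported only as a limit.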

Compound 4, half-maximal cytotoxic concentration: > 10000 nM
Compound 4 gave a limit, no number; the forecaster's own chance of this, stated with the estimate: 70%; the middle value lies on the limit itself.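

Within the data shown here, compound 4, like compound 1, compound 2 and compound 3, gives only a limit of the assay, so no step between compound 4 and any of them can be read. The compounds shown leave open whether these four differ at all in this assay.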